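A few compounds are considered here, and "the series" means these few. Any claim that something is new, unique, unknown or untested is made for them only; others in the source may bear on it.

The measured compounds:
compound 1 `CC(C)c1ccnc(C(=O)Nc2nn[nH]n2)c1` — 34%
compound 2 `Cc1cc(C)nc(C(=O)Nc2nn[nH]n2)c1` — 44%

Both were tested in a functional assay on the whole organism for inhibition, with Rattus norvegicus as the target, at a dose of 3 mg/kg by the oral route; a lower number here means a weaker effect, a higher number a stronger effect of the compound at the dose given. Compound 1 stands at 34% in this assay , and compound 2 at 44% sits within the usual scatter of it, so the two are not told apart. Compound 3 `O=C(Nc1nn[nH]n1)c1cc(Cl)ccn1` has not been measured. It differs from compound 1 in one place: chloro in place of isopropyl on an aromatic carbon. Among the measured compounds shown here, no measured pair shows what such a change does here, so a step within the scatter is expected: a number 2 percentage points higher from compound 1 to compound 3 (within the scatter). Compound 3 is expected to give about 36%, within a range from 15% to 58%.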

Compound 3, a percentage reported as inhibition, in the whole organism at one dose (the size of the read-out at that dose, not a potency): 72%
Estimate against measurement, compound 3: 36 percentage points below; measured number above the stated range.
By their numbers in this assay, from the lowest: compounds 1 and 2 (each within the scatter of the next); then compound 3.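

In this assay, chloro in place of isopropyl on an aromatic carbon, opposite the ring nitrogen, gives a number 38 percentage points higher from compound 1 to compound 3 (beyond the scatter). Among the compounds shown here, this shows that the group at this position can change the effect at this dose, something the earlier compounds, with no single-place change between them, could not show. No measurement at hand accounts for the step.

Going by these compounds, whether the step comes from the arrival of chloro or the departure of isopropyl remains open. A fluoro, methoxy or amine group at this position would help separate the two.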